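Chloro in Place of Methyl: Expected Toxicity of Compound 3

The source may report more compounds than this note shows. Statements on the series, on what has been measured and on what is new or still open speak of the compounds shown alone.

Compound 1 `Cc1ccc(-c2nn(-c3ccccc3)cc2C(=O)NOCc2ccccc2Cl)cc1` was tested in an ADME assay on HEK-293T cells (Homo sapiens) for antiproliferative activity, read by MTT assay, with a stated time of 48 h, in the presence of a further agent that is not named here (on this read-out higher numbers stand for lower toxicity in this test and lower numbers for higher toxicity in this test), where compound 1 gives 38700 nM. Its companion compound 2 `Cc1ccc(-c2nn(-c3ccccc3)cc2C(=O)NOCc2ccc(Cl)cc2Cl)cc1` gives 39600 nM in the same test. Among the measured compounds shown here, the only measured step, a 1.0-fold higher number from compound 1 to compound 2 (0.01 log units; within the scatter), comes from chloro in place of hydrogen on an aromatic carbon. Compound 1 therefore stands next to compound 2, the two numbers separated by a step that is within the scatter.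

Compound 3 `O=C(NOCc1ccccc1Cl)c1cn(-c2ccccc2)nc1-c1ccc(Cl)cc1` has not yet been measured. It differs from compound 1 by chloro in place of methyl on an aromatic carbon. For the measured compounds named here, no measured step matches this change directly; the one step available, a 1.0-fold higher number from compound 1 to compound 2 (0.01 log units; within the scatter), shows a chloro entering elsewhere without moving the number beyond the scatter. The two measured compounds sit close together, and nothing in them points to a large move in either direction. The step of a 1.0-fold higher number from compound 1 to compound 3 (0.01 log units; within the scatter) is therefore expected to stay within the scatter. For compound 3 the estimated value is 40000 nM, with a range from 20000 nM to 80000 nM.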

Compound 3, half-maximal cytotoxic concentration: 129000 nM
Compound 3: the middle estimate sits 3.2-fold (0.51 log units) below what was measured; measured number above the stated range.
By their numbers in this assay, from the lowest: compounds 1 and 2 (each within the scatter of the next); then compound 3.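

Replacing the methyl with a chloro, which turns the 4-methylphenyl into a 4-chlorophenyl, gives a 3.3-fold higher number from compound 1 to compound 3 (0.52 log units; beyond the scatter) in this assay, so this position on an aromatic carbon, para to a large group, can shift the number beyond the scatter, towards lower toxicity in this test. The earlier step, a 1.0-fold higher number from compound 1 to compound 2 (0.01 log units; within the scatter), had shown only that a chloro entering elsewhere on the molecule left the number within the scatter, so the two steps together show that a chloro's entry does not read the same at both places, although the step at this position is modest and the change there is a swap rather than an addition. No measurement given here accounts for the shift, and the data offer no explanation for it.

The compounds shown leave open whether the higher number follows from the methyl leaving, the chloro entering or both, a question that plain hydrogen at this place could help to separate. They also leave open how far the number would move with another group here, such as fluoro, methoxy or an amine, and whether the 2,4-dichloro pattern of compound 2 would combine with the 4-chlorophenyl.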